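From Compound 2 to Compound 3: One Group Exchanged

A few compounds are considered here, and "the series" means these few. Any claim that something is new, unique, unknown or untested is made for them only; others in the source may bear on it.

- compound 1 `Nc1nc(Nc2ccc(S(N)(=O)=O)cc2)sc1C(=O)c1cccnc1` gives 13000 nM
- compound 2 `Nc1nc(Nc2ccc(S(N)(=O)=O)cc2)sc1C(=O)c1ccccc1[N+](=O)[O-]` gives 16000 nM

In a functional assay on TM4 cells (Mus musculus) for cytotoxicity, read by MTT assay, with a stated time of 72 h (on this read-out higher numbers stand for weaker inhibition and lower numbers for stronger inhibition), compound 2 stands at 16000 nM, level with compound 1 within the usual scatter. Compound 3 `Nc1nc(Nc2ccc(S(N)(=O)=O)cc2)sc1C(=O)c1cccc(F)c1` has not yet been measured. It differs from compound 2 by having 3-fluorophenyl in place of 2-nitrophenyl on a carbonyl carbon. Among the measured compounds shown here, only one measured step bears on this change. That step, a 1.2-fold higher number from compound 1 to compound 2 (0.09 log units; within the scatter), also exchanged the group at this place, so no step beyond the scatter is expected in this assay. For the measured compounds named here, this is thin evidence, as no measured compound carries a fluorine. The expected step is a 1.1-fold lower number from compound 2 to compound 3 (0.06 log units; within the scatter). For compound 3 the estimated value is 14000 nM, with an expected range from 6000 nM to 30000 nM.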

Compound 3, half-maximal inhibitory concentration: 4800 nM
Beside the measured number, compound 3's estimate is 2.9-fold (0.46 log units) above it, outside the stated range (below it).
By their numbers in this assay, from the lowest: compound 3; then compounds 1 and 2 (each within the scatter of the next).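

In this assay, 3-fluorophenyl on the carbonyl carbon gives a 3.3-fold lower number from compound 2 to compound 3 (0.52 log units; beyond the scatter), and measured against pyridin-3-yl it gives a 2.7-fold lower number from compound 1 to compound 3 (0.43 log units; beyond the scatter). Among the compounds shown here, the two earlier groups sat level within the scatter, so this is the first sign that the group at this place can move the number beyond the scatter, though both steps are modest. Nothing at hand explains why 3-fluorophenyl stands apart from the other two groups.

The compounds shown cannot separate the effect of the fluorine from that of the ring carrying it, and a plain phenyl group or a phenyl bearing a chlorine or a methoxy group would speak to that. Also open, from the compounds shown here alone, is how the rest of the core contributes, since it stays the same in all three compounds.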